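The source may report more compounds than this note shows. Statements on the series, on what has been measured and on what is new or still open speak of the compounds shown alone.

The compounds were examined in an ADME assay on microsomes from liver (Mus musculus, strain NMRI) for metabolic stability, tested at 2.5 uM; on this read-out higher numbers stand for fast clearance and lower numbers for slow clearance. Compound 1 `Fc1cc(C(F)(F)F)ccc1-c1ccc(Cn2nnc3ccccc32)cc1` gives 1.2 mL/min/g in this assay. Compound 2 `Fc1cc(Cl)ccc1-c1ccc(Cn2nnc3c(F)cccc32)cn1` gives 2.2 mL/min/g. Compound 3 `Fc1ccc2c(c1)nnn2Cc1ccc(-c2ccc(Cl)cc2F)nc1` gives 0.7 mL/min/g. Compound 2 and compound 1 lie within the usual scatter of each other, so no order can be read between them, while compound 3 sits lower than compound 2 by a margin beyond that scatter.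

Compound 4 `Fc1cc(Cl)ccc1-c1ccc(Cn2nnc3c(C(F)(F)F)cccc32)cn1` has not yet been measured. It differs from compound 2 in one place: trifluoromethyl in place of fluoro on an aromatic carbon. Among the measured compounds shown here, no measured pair shows this change, so the data give no direct guide. A small step is expected in this assay, a 1.1-fold higher number from compound 2 to compound 4 (0.06 log units; within the scatter), not going beyond the scatter. Compound 4 is therefore estimated at 2.5 mL/min/g, within a range from 1.2 mL/min/g to 5 mL/min/g.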

Compound 4, intrinsic clearance in a liver preparation (reported as CLH), per the amount of preparation that the assay uses: 0.1 mL/min/g
Compound 4: middle estimate off by 25-fold (1.40 log units), on the high side; the whole stated range lies above it.
By their numbers in this assay, from the lowest: compound 4; then compounds 3, 1 and 2 (each within the scatter of the next, the first and the last beyond it).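

In this assay, trifluoromethyl in place of fluoro on this aromatic carbon gives a 22-fold lower number from compound 2 to compound 4 (1.34 log units; beyond the scatter), a large step for a change of one substituent. Among the compounds shown here, no earlier pair of compounds isolated a change at this position, so its strong response to the group placed there is new information. This single pair shows the size of the step for this one change, and gives no general rule. Going by these compounds, whether a methyl, an amine or a carboxylic acid on the same carbon would give a step of similar size remains open. Nothing available here explains the size of this step.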